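The source may hold more compounds than are shown below. What is called first, only, known or untested is meant among the compounds shown, and "the series" means these compounds.

Working notes on the series. The shared core appears in four compounds: compound 1 `COc1ccccc1/C=c1\c(=O)[nH]/c(=C/c2ccccc2Cl)c(=O)n1C`, compound 2 `C=CCn1c(=O)/c(=C\c2ccccc2OC)[nH]c(=O)/c1=C\c1ccccc1OC`, compound 3 `COc1ccccc1/C=c1/[nH]c(=O)/c(=C\c2ccccc2OC)n(C)c1=O` and compound 4 `C=CCn1c(=O)/c(=C\c2ccccc2Cl)[nH]c(=O)/c1=C\c1ccccc1OC`. In a functional assay on MOLT-4 cells (Homo sapiens) for cytotoxicity, read by CCK-8 assay, with a stated time of 72 h (on this read-out higher numbers stand for weaker inhibition and lower numbers for stronger inhibition), compound 2 gives 13100 nM. In this assay compound 1 gives "not determined" (no result reported). In this assay compound 3 gives "not determined" (no result reported). For the measured compounds named here, compound 2 is therefore the only member of the set with a number, and nothing can be said of its standing relative to the others; no step between measured compounds exists.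

Compound 4 differs from compound 2 in one place: chloro in place of methoxy on an aromatic carbon, on an aromatic carbon of a six-membered aromatic ring of carbon only. Going by the values given here, no measured pair in the set carries this same change, so its effect is unknown here. With a single data point, the expectation is that compound 4 lands close to compound 2, and the step of a 1.0-fold lower number from compound 2 to compound 4 (0.00 log units; within the scatter) is expected to stay within the scatter, in no particular direction. Compound 4 is estimated at 13000 nM, with a range from 5000 nM to 35000 nM.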

Compound 4, half-maximal inhibitory concentration: 4400 nM
The estimate for compound 4 lay 3.0-fold (0.47 log units) above the measured number; measured number outside the range, below it.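

In this assay, for the compounds shown here, the exchange of 2-methoxyphenyl for 2-chlorophenyl gives a 3.0-fold lower number from compound 2 to compound 4 (0.47 log units; beyond the scatter), the first step that can be read, and it shows that the number responds to the group on this aromatic carbon, ortho to a large group. Methoxy counts a hydrogen-bond acceptor and chloro none, but a single pair cannot say whether that difference matters. Nothing measured here accounts for the step.

Steps involving compound 1 and compound 3 cannot be read, as neither has a number. As far as these compounds go, it remains open how fluoro, bromo, an amine or a hydroxyl would fare on this carbon, and whether the same exchange on the second 2-methoxyphenyl group would move the number in the same direction.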